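Isopropyl in place of methyl on compound 2

A few compounds are considered here, and "the series" means these few. Any claim that something is new, unique, unknown or untested is made for them only; others in the source may bear on it.

Of the compounds shown here, three with a shared core have been tested in a functional assay on SW620/5-FU cells (Homo sapiens) for cytotoxicity, read by MTT assay, with a stated time of 48 h, in the presence of a further agent that is not named here; on this read-out higher numbers stand for an effect only at larger amounts of compound and lower numbers for an effect already at smaller amounts. Compound 1 `Cn1nc(C(F)(F)F)c2c(-c3ccccc3)cc(NNC(=O)Nc3cc(Cl)nc(Cl)c3)nc21` gives 13100 nM, compound 2 `COc1ccc(-c2cc(NNC(=O)Nc3cc(Cl)nc(OC)c3)nc3c2cnn3C)cc1` gives 48800 nM, and compound 3 `COc1cc(NC(=O)NNc2cc(-c3ccc(F)cc3)c3cnn(C)c3n2)cc(Cl)n1` gives 24100 nM. Compound 2 thus stands highest of the three numbers, with compound 3 nearest and compound 1 furthest. Going by the values given here, the only step between compounds that differ in one place is a 2.0-fold lower number from compound 2 to compound 3 (0.31 log units; beyond the scatter), a fluoro in place of methoxy on an aromatic carbon of the other aromatic ring.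

Compound 4 `COc1ccc(-c2cc(NNC(=O)Nc3cc(Cl)nc(OC(C)C)c3)nc3c2cnn3C)cc1` has not yet been measured. It differs from compound 2 by isopropyl in place of methyl on an oxygen on an aromatic ring, which read one bond further out is methoxy to isopropoxy, or 2-chloro-6-methoxypyridin-4-yl to 2-chloro-6-isopropoxypyridin-4-yl. Among the compounds with values here, no measured step touches this position, and the step from compound 2 to compound 3 lies elsewhere, so it offers no direct guide. With nothing to point either way, the expected change in this assay is none beyond the scatter, and compound 4 is expected to give 42000 nM, with a range from 15000 nM to 110000 nM. The expected step is a 1.2-fold lower number from compound 2 to compound 4 (0.07 log units; within the scatter).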

Compound 4, half-maximal effective concentration: 47100 nM
Estimate against measurement, compound 4: 1.1-fold (0.05 log units) below, and the stated range covers the measured number.
By their numbers in this assay, from the lowest: compounds 1, 3, 4 and 2 (each within the scatter of the next, the first and the last beyond it).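

Isopropyl in place of methyl on an oxygen on an aromatic ring gives a 1.0-fold lower number from compound 2 to compound 4 (0.02 log units; within the scatter) in this assay, the first reading at this place, since the earlier step from methoxy to fluoro lay on the other aromatic ring. Going from methoxy to isopropoxy on the 2-chloropyridine part therefore leaves the number within the scatter, so the larger alkyl group on this oxygen is accepted here without a measurable change. Nothing available bears on why the two compounds read alike.

On these data alone, it remains open whether this holds for a longer chain such as n-butoxy, a free hydroxyl or an amine at the same place. The compounds also leave open whether isopropoxy would read the same way alongside the 4-fluorophenyl group of compound 3.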